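A few compounds are considered here, and "the series" means these few. Any claim that something is new, unique, unknown or untested is made for them only; others in the source may bear on it.

Measured in a physicochemical assay for lipophilicity; on this read-out higher numbers stand for higher lipophilicity and lower numbers for lower lipophilicity:
compound 1 `Cc1cc(Cl)c(-c2cn(C)c(C)n2)cc1NC(=O)c1ccc(OCc2ccccn2)cc1` gives 3.3
compound 2 `Cc1ccc(-c2cnc(C)n2C)cc1NC(=O)c1ccc(OCc2ccccn2)cc1` gives 2.8
compound 3 `Cc1cc(C)c(-c2cn(C)cn2)cc1NC(=O)c1ccc(OCc2ccccn2)cc1` gives 3

All three share one core and differ only in the small aromatic ring attached to it and in the methyl groups around it. Compound 3 has compound 2 as its nearest neighbour and compound 1 as its furthest, yet both gaps lie within the usual scatter of repeated measurements, so the three cannot be told apart in this assay. Compound 4 `Cc1cc(C)c(-c2ccc(N)cn2)cc1NC(=O)c1ccc(OCc2ccccn2)cc1` has not yet been measured. It differs from compound 3 in one place: 5-aminopyridin-2-yl in place of 1-methyl-1H-imidazol-4-yl on an aromatic carbon. Within the data shown here, no measured pair shows this exact change, so the data give no step to lean on. A step from compound 3 to compound 4 of a number 0.20 log units lower from compound 3 to compound 4 (within the scatter) is expected, not beyond the scatter. The estimate for compound 4 is 2.8, with a range from 2.3 to 3.4.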

Compound 4, distribution coefficient: 3.2
Beside the measured number, compound 4's estimate is 0.40 log units below it, within the range that was stated.
By their numbers in this assay, from the lowest: compounds 2, 3, 4 and 1 (each within the scatter of the next, the first and the last beyond it).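

In this assay, 5-aminopyridin-2-yl in place of 1-methyl-1H-imidazol-4-yl gives a number 0.20 log units higher from compound 3 to compound 4 (within the scatter). At this position, ortho to a methyl group and para to a methyl group, a five-membered aromatic ring can thus give way to a six-membered one carrying an amine with no change that this read-out can resolve. Nothing available offers a reason for this result. The compounds shown leave open whether the reading would also stay within the scatter with a carboxylic acid or a methoxy group in place of the amine.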